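This account rests on a few compounds, and the source may have more. Where it says the series, first, only, none or still open, it means among the compounds named here.

Of the compounds shown here, two with the same polybrominated core have so far been measured. Compound 1 `OC(CCn1nc2c(Br)c(Br)c(Br)c(Br)c2n1)c1ccccc1` carries a 3-hydroxy-3-phenylpropyl chain and, in a functional assay on MCF7 cells (Homo sapiens) for antiproliferative activity, read by MTT assay, with a stated time of 48 h, tested at 25 uM (on this read-out lower numbers stand for a stronger effect and higher numbers for a weaker effect at the one concentration tested), compound 1 gives 105%. Compound 2 `C[C@H](O)CCn1nc2c(Br)c(Br)c(Br)c(Br)c2n1` carries a 3-hydroxybutyl chain instead; in this assay compound 2 gives 89%. Compound 2 thus stands lowest of the two numbers, and its gap to compound 1 is beyond the scatter, so of the two it shows the stronger effect at the tested concentration.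

Compound 3 `OCC(O)Cn1nc2c(Br)c(Br)c(Br)c(Br)c2n1` has not yet been measured. It differs from compound 2 in one place: 1,2-dihydroxyethyl in place of 2-hydroxypropyl on a saturated chain carbon bound to an aromatic nitrogen. For the measured compounds named here, no step between measured compounds covers this kind of change, so the expectation rests on compound 2 alone. A step of modest size, if any, is expected, leaning toward a weaker effect, with the step from compound 2 to compound 3 in this assay estimated as a number 6 percentage points higher from compound 2 to compound 3 (within the scatter). Compound 3 is expected to give about 95%, within roughly 80% to 110%.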

Compound 3, a percentage reported as activity, at one concentration (the size of the read-out at that concentration, not a potency): 111%
Compound 3: middle estimate off by 16 percentage points, on the low side, and the stated range ends below it.
By their numbers in this assay, from the lowest: compound 2; then compounds 1 and 3 (each within the scatter of the next).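

The swap of 2-hydroxypropyl for 1,2-dihydroxyethyl on a saturated chain carbon bound to an aromatic nitrogen is not a silent one: with the heavy-atom count unchanged, this assay moves a number 22 percentage points higher from compound 2 to compound 3 (beyond the scatter), so this position responds to an exchange of a carbon for an oxygen and the effect seen with compound 2 does not carry over. The change adds a hydrogen-bond donor and acceptor and also removes the defined stereocentre, and this single pair cannot separate these differences. Nothing available here explains the rise.

Open, on these data alone, is whether an amine or a methoxy group in place of the added hydroxyl would keep or deepen the effect of compound 2. Also open, as far as these compounds go, is how a carboxylic acid or a longer chain would read at this position.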